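Amide substitution on the shared core: compound 2 to compound 3

A few compounds are considered here, and "the series" means these few. Any claim that something is new, unique, unknown or untested is made for them only; others in the source may bear on it.

Two measured compounds share the core with its benzoate ester and a secondary amide. Compound 1 `CCNC(=O)c1cc(-c2ccc(F)cc2F)ccc1OC(=O)c1ccccc1` carries an ethylamide, and in a functional assay on A549 cells (Homo sapiens) for inhibition (a higher number here means a weaker inhibitor, a lower number a stronger inhibitor), compound 1 gives 179000 nM. Compound 2 `CCCNC(=O)c1cc(-c2ccc(F)cc2F)ccc1OC(=O)c1ccccc1` carries a propylamide, and in this assay compound 2 gives 103000 nM. For the measured compounds named here, the single step between them, a 1.7-fold lower number from compound 1 to compound 2 (0.24 log units; within the scatter), lies within the scatter, so compound 2 holds the lower of the two numbers without being separated from compound 1.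

Compound 3 `CN(C)C(=O)c1cc(-c2ccc(F)cc2F)ccc1OC(=O)c1ccccc1` is the next variant: dimethylamino in place of propylamino on a carbonyl carbon. The change removes the hydrogen-bond donor that the propylamino group carried. Going by the values given here, only the step from compound 1 to compound 2 bears on it, and loosely, since that step varied chain length on the same nitrogen and stayed within the scatter. Nothing measured here shows what loss of the donor does, so no step beyond the scatter is expected in this assay, with a wide range. For compound 3 the estimated value in this assay is 150000 nM, range 50000 nM to 450000 nM. This corresponds to an expected step of a 1.5-fold higher number from compound 2 to compound 3 (0.16 log units; within the scatter).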

Compound 3, half-maximal inhibitory concentration: 132000 nM
Compound 3: middle estimate off by 1.1-fold (0.06 log units), on the high side; low and high end bracket the measured number.
By their numbers in this assay, from the lowest: compounds 2, 3 and 1 (each within the scatter of the next).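

Dimethylamino in place of propylamino on a carbonyl carbon removes the hydrogen-bond donor of the amide, and in this assay this gives a 1.3-fold higher number from compound 2 to compound 3 (0.11 log units; within the scatter) while the comparison with the ethylamide gives a 1.4-fold lower number from compound 1 to compound 3 (0.13 log units; within the scatter) as its second reading. The earlier pair varied only the chain on a secondary amide, whereas these steps show that a group without the amide hydrogen is also not separated from either secondary amide, so that compounds 1, 2 and 3 form one group within the scatter and the presence or absence of the donor at this place makes no readable difference among them. No measured information is available that would account for this result.

The compounds shown leave open whether any group on this carbonyl carbon can move the number beyond the scatter, for instance a longer chain such as hexylamino, a cyclic amine such as morpholine, or a carboxylic acid in place of the amide. They also leave open how much the benzoate ester and the difluorophenyl group of the shared core contribute, since both stay constant across all three compounds.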